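A few compounds are considered here, and "the series" means these few. Any claim that something is new, unique, unknown or untested is made for them only; others in the source may bear on it.

Compound 1 `Nc1c(C(=O)NC2CCCC2)oc2nc(-c3ccccc3)cc(C(F)(F)F)c12` gives 32400 nM in a functional assay on HepG2 cells (Homo sapiens) for antiproliferative activity, read by MTT assay (on this read-out lower numbers stand for stronger inhibition and higher numbers for weaker inhibition), the highest of the two numbers at hand; compound 2 `CNC(=O)c1oc2nc(-c3cccs3)cc(C(F)(F)F)c2c1N` gives 12300 nM in this assay, and the gap between the two lies beyond the scatter. Compound 3 `Cc1ccc(/C=N/NC(=O)c2oc3nc(-c4ccccc4)cc(C(F)(F)F)c3c2N)cc1` is not yet measured. It differs from compound 1 in a group of 9 heavy atoms (8 carbon, 1 nitrogen; one six-membered aromatic ring of carbon only) in place of a group of 5 heavy atoms (5 carbon; one five-membered non-aromatic ring of carbon only), on an amide-type nitrogen, the entering group carrying one double bond outside aromatic rings. For the measured compounds named here, no measured pair shows a change of this kind, so the direction is open; a step of modest size in either direction, or none beyond the scatter, is expected. Compound 3 is expected to give 20000 nM in this assay, within 5000 nM to 80000 nM. The expected step is a 1.6-fold lower number from compound 1 to compound 3 (0.21 log units; within the scatter) in this assay.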

Compound 3, half-maximal inhibitory concentration: 8900 nM
Beside the measured number, compound 3's estimate is 2.2-fold (0.35 log units) above it; measured number inside the range.
By their numbers in this assay, from the lowest: compounds 3 and 2 (each within the scatter of the next); then compound 1.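

At the amide-type nitrogen, cyclopentyl is not required for activity in this assay: the group with a six-membered aromatic ring and a double bond outside it gives a step beyond the scatter (a 3.6-fold lower number from compound 1 to compound 3 (0.56 log units; beyond the scatter)). For the compounds shown here, this is the first readable step at this position, and it runs towards a lower number. No measurement on these compounds gives a cause for the step.

A benzyl group on the same nitrogen would help separate the part played by the aromatic ring from that of the double bond. Going by these compounds, how a morpholine or a carboxylic acid would behave at this position also remains open.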